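Aromatic group change from compound 3 to compound 4

The source may hold more compounds than are shown below. What is called first, only, known or untested is meant among the compounds shown, and "the series" means these compounds.

- compound 1 `CCCS(=O)(=O)N1CCN(C2(CNC(=O)c3ccccc3C(F)(F)F)CCCCC2)CC1`: 5%
- compound 2 `CCCS(=O)(=O)N1CCN(C2(CNC(=O)c3ccccc3OC(F)(F)F)CCCCC2)CC1`: 2%
- compound 3 `CCCS(=O)(=O)N1CCN(C2(CNC(=O)c3ccc(F)cc3C)CCCCC2)CC1`: 2%

All three values come from an ADME assay on microsomes from liver (Homo sapiens) for metabolic stability, with a stated time of 60 min, tested at 10 uM; on this read-out higher numbers stand for a more stable compound and lower numbers for a less stable compound. Compound 3 is level with compound 2 at the digits shown, and both lie within the scatter of compound 1.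

Compound 4 `CCCS(=O)(=O)N1CCN(C2(CNC(=O)c3c(Cl)cccc3Cl)CCCCC2)CC1` carries 2,6-dichlorophenyl in place of 4-fluoro-2-methylphenyl on a carbonyl carbon.

For the measured compounds named here, three measured steps bear on this change: a number 3 percentage points lower from compound 1 to compound 3 (within the scatter), no change at the digits printed from compound 2 to compound 3 (within the scatter) and a number 3 percentage points lower from compound 1 to compound 2 (within the scatter). Each alters the same aromatic part of the molecule, and none goes beyond the scatter. Going by the values given here, no measured compound carries 2,6-dichlorophenyl, so this group remains untested, and the expectation rests on those small steps alone.

No change beyond the scatter is therefore expected, and the expected step is a number 3 percentage points higher from compound 3 to compound 4 (within the scatter). In this assay the estimated value for compound 4 is 5%, with an expected range from 1% to 15%.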

Compound 4, percent of the compound remaining: 3%
The estimate for compound 4 lay 2 percentage points above the measured number; measured number inside the range.
By their numbers in this assay, from the lowest: compounds 2, 3, 4 and 1 (each within the scatter of the next).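

In this assay, 2,6-dichlorophenyl on the carbonyl carbon stays within the scatter of all three earlier aromatic groups, with steps of (a number 1 percentage points higher from compound 3 to compound 4 (within the scatter)), (a number 1 percentage points higher from compound 2 to compound 4 (within the scatter)) and (a number 2 percentage points lower from compound 1 to compound 4 (within the scatter)). The series now holds four aromatic groups at this place, and the entry of two chlorine atoms, with the fluorine and the methyl gone, separates compound 4 from none of compounds 1, 2 and 3. No measurement at hand accounts for this result.

As far as these compounds go, it remains open whether any group at this place can move the read-out beyond the scatter, for instance an aromatic ring carrying a carboxylic acid or an amine. Also open, from the compounds shown here alone, is whether a change elsewhere on the shared core, such as a longer chain on the sulfonyl group, would do so.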